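The source may report more compounds than this note shows. Statements on the series, on what has been measured and on what is new or still open speak of the compounds shown alone.

Compound 1 `COc1ccc2c(/C=C/C(=O)c3cc(N)c(OC)c(OC)c3)c[nH]c2c1` and compound 2 `COc1ccc2c(/C=C/C(=O)c3cc(N)c(OC)c(OC)c3)cn(C)c2c1` share one core and differ in a single spot: methyl in place of hydrogen on an aromatic nitrogen. In a functional assay on HCT-8 cells (Homo sapiens) for antiproliferative activity, read by MTT assay, with a stated time of 48 h (on this read-out lower numbers stand for stronger inhibition and higher numbers for weaker inhibition), compound 1 gives 368 nM, and in the same assay compound 2 gives 455 nM. This gives a 1.2-fold higher number from compound 1 to compound 2 (0.09 log units; within the scatter), so the two values cannot be told apart with confidence.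

Compound 3 `COc1cc(C(=O)/C(C)=C/c2c[nH]c3ccccc23)cc([Se]C)c1OC` is built on a different core; how its core differs from that of compound 1 is not broken down here. In this assay compound 3 gives 32 nM, the lowest number of the three, and its distance to compound 1 and to compound 2 lies beyond the scatter in both cases, so compound 3 is the most potent of the measured set.

Compound 4 `COc1cc(C(=O)/C(C)=C/c2cn(C)c3ccccc23)cc([Se]C)c1OC` is not yet measured. It stands to compound 3 as compound 2 stands to compound 1: methyl in place of hydrogen on an aromatic nitrogen. The place of the change is described in the same words for both pairs, so this is the same change applied to a second core.

Going by the values given here, the only guide is the earlier pair. The step from compound 3 to compound 4 is expected to be a 1.3-fold higher number from compound 3 to compound 4 (0.10 log units; within the scatter), because a 1.2-fold higher number from compound 1 to compound 2 (0.09 log units; within the scatter). Carrying that over, compound 4 is estimated to give about 40 nM in this assay. Allowing for the scatter and for the change of core, compound 4 is expected to fall between 15 nM and 100 nM.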

Compound 4, half-maximal inhibitory concentration: 48 nM
Compound 4: middle estimate off by 1.2-fold (0.08 log units), on the low side, and the stated range covers the measured number.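

In this assay, methyl in place of hydrogen on the aromatic nitrogen gives a 1.5-fold higher number from compound 3 to compound 4 (0.18 log units; within the scatter) and so, as on the first core, the two values cannot be told apart with confidence. Set side by side, the steps on the two cores do not differ from each other, so in this small series the change carries over from one core to the other without a detectable shift in the read-out: the same change on two cores in this assay, a 1.2-fold higher number (0.09 log units; within the scatter) from compound 1 to compound 2 and a 1.5-fold higher number (0.18 log units; within the scatter) from compound 3 to compound 4, 1.2-fold (0.08 log units) apart, within the scatter of two such steps. This shows only that the hydrogen on this nitrogen can be exchanged for methyl on these two cores with no change that stands clear of the usual scatter; it does not show that methyl has any real effect of its own, that the same would hold on a third core, or why the result comes out this way.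

The compounds shown leave open what a larger group on the same nitrogen, such as ethyl, a longer chain, benzyl or a chain ending in an amine or a carboxylic acid, would do to the read-out. They also leave open which feature accounts for the gap between the two cores, since compound 1 and compound 3 differ in more than one place.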